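This account rests on a few compounds, and the source may have more. Where it says the series, first, only, none or still open, it means among the compounds named here.

Measured in an ADME assay on microsomes from liver (Mus musculus, strain CD-1) for metabolic stability, read by LC-MS, tested at 2 uM; on this read-out lower numbers stand for a shorter-lived compound and higher numbers for a longer-lived compound:
- Compound 1 `CN(C)C(=O)c1ccncc1Nc1cc(-c2ccc3ccn(C)c3c2)c2nccnc2c1`: 0.35 h
- Compound 2 `CN1CCC(NC(=O)c2ccncc2Nc2cc(-c3ccc4ccn(C)c4c3)c3nccnc3c2)CC1`: > 1 h

The reading for compound 2, > 1 h, is a limit of the assay and not a number.

Compound 3 `CC(=O)N1CCCC(NC(=O)c2ccncc2Nc2cc(-c3ccc4ccn(C)c4c3)c3nccnc3c2)C1` keeps the shared core and the amide, but carries 1-acetylpiperidin-3-yl in place of 1-methylpiperidin-4-yl on an amide-type nitrogen. For the measured compounds named here, no measured compound holds this new group, so only one measured step bears on the change. That step is an at least 2.8-fold higher number from compound 1 to compound 2 (0.45 log units; beyond the scatter), in which (1-methylpiperidin-4-yl)amino took the place of dimethylamino on a carbonyl carbon. Compound 3 still has a six-membered non-aromatic ring at that place, so the gain seen in an at least 2.8-fold higher number from compound 1 to compound 2 (0.45 log units; beyond the scatter) is expected to carry over largely, though a single step is thin support. The expected change is a number no higher from compound 2 to compound 3 (the limit leaves the size open), an estimate that should stay within the usual scatter. For compound 3 the estimated half-life in this assay is 1 h, with an expected range of 0.45 h to 2.2 h.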

Compound 3, half-life: 0.4 h
Beside the measured number, compound 3's estimate is 2.5-fold (0.40 log units) above it, and the stated range ends above it.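

In this assay, a six-membered non-aromatic ring on the amide-type nitrogen does not by itself secure the longer half-life: 1-acetylpiperidin-3-yl in place of 1-methylpiperidin-4-yl gives an at least 2.5-fold lower number from compound 2 to compound 3 (0.39 log units; beyond the scatter). Measured against the much smaller dimethylamino group, (1-acetylpiperidin-3-yl)amino gives a 1.1-fold higher number from compound 1 to compound 3 (0.06 log units; within the scatter), so the gain seen with the 1-methylpiperidin-4-yl group does not appear with this ring, and the ring's size alone does not account for that gain. The first of these steps gives only a minimum size, as it rests on a limit of the assay and not on a number: the limit of > 1 h in this assay, at which 1 of the 3 values shown sits.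

This change alters two things at once, the group on the ring nitrogen (methyl to acetyl) and the ring's point of attachment (4-yl to 3-yl), and the compounds shown cannot say which of the two matters for the half-life. A 1-methylpiperidin-3-yl or a 1-acetylpiperidin-4-yl group would pull these two apart, and a plain cyclohexyl ring would show whether the ring nitrogen is needed at all.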